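This account rests on a few compounds, and the source may have more. Where it says the series, first, only, none or still open, it means among the compounds named here.

The measured compounds and their values in an ADME assay on RD cells (Homo sapiens) for cytotoxicity, read by MTT assay, with a stated time of 24 h; a lower number here means that less compound is tolerated, a higher number that more compound is tolerated:

Compound 1, `CC(CCOc1ccc(-c2noc(C(C)(C)C)n2)cc1)CCN1CCN(c2ccnc(N)c2)C1=O`, gives 55000 nM.
Compound 2, `Cc1nc(-c2ccc(OCCC(C)CCN3CCN(c4ccnc(N)c4)C3=O)cc2)no1`, gives 66100 nM.
Compound 3, `CCCc1nc(-c2ccc(OCCC(C)CCN3CCN(c4ccnc(N)c4)C3=O)cc2)no1`, gives only a limit of this assay, > 100000 nM.

All three values sit high, and the steps among them are small: a 1.2-fold higher number from compound 1 to compound 2 (0.08 log units; within the scatter), an at least 1.8-fold higher number from compound 1 to compound 3 (0.25 log units; that floor lies within the scatter) and an at least 1.5-fold higher number from compound 2 to compound 3 (0.17 log units; that floor lies within the scatter). Among the compounds with values here, compound 3 is the one whose reading is the limit of > 100000 nM in this assay, at which 1 of the 3 values shown sits, so its true value is not pinned down, only its floor. Compound 4, `CC(CCOc1ccc(/C=N/O)cc1)CCN1CCN(c2ccnc(N)c2)C1=O`, differs from compound 3 by a group of 3 heavy atoms (1 carbon, 1 nitrogen, 1 oxygen; no ring) in place of a group of 8 heavy atoms (5 carbon, 2 nitrogen, 1 oxygen; one five-membered aromatic ring with 3 hetero atoms), on an aromatic carbon. Within the data shown here, none of the measured steps changes that part of the molecule in the same way; they only swap the small substituents on the five-membered ring that now leaves entirely. The measured steps therefore bear on this change only loosely, but every one of them stays within the scatter at high values, which gives no reason to expect a move beyond the scatter in this assay. The expected step of an at least 1.2-fold lower number from compound 3 to compound 4 (0.09 log units; that floor lies within the scatter) is small. Compound 4 is accordingly estimated at about 80000 nM, within a range from 30000 nM to 150000 nM, with a fair chance that this assay again reports only a limit.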

Compound 4, half-maximal cytotoxic concentration: > 100000 nM
Compound 4 gave a limit, no number; the forecaster's own chance of this, stated with the estimate: 45%; middle value at least 1.2-fold (0.09 log units) from the limit.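

Compound 4 shows that this aromatic carbon, para to a large group, can lose the whole five-membered ring, not only the small substituent on it, without the reading in this assay coming down. Its reading is a limit, as is that of compound 3, so the step between them cannot be read: the limit of > 100000 nM in this assay, at which 2 of the 4 values shown sit. The two readable steps, an at least 1.5-fold higher number from compound 2 to compound 4 (0.17 log units; that floor lies within the scatter) and an at least 1.8-fold higher number from compound 1 to compound 4 (0.25 log units; that floor lies within the scatter), give only floors, so they show no real rise, only that the smaller, ring-free group of 3 heavy atoms leaves the number as high as those of the compounds carrying the ring.

Going by these compounds, how far compound 3 and compound 4 truly lie past the limit stays unknown. Also open, on these data alone, is whether an amine or a carboxylic acid on this aromatic carbon would keep the number this high.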